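From isopropyl to methyl on a sulfonamide nitrogen

This account rests on a few compounds, and the source may have more. Where it says the series, first, only, none or still open, it means among the compounds named here.

Within the data shown here, in an in vitro ADME assay on microsomes from liver (Rattus norvegicus) for metabolic stability, read by LC-MS, tested at 1 uM (on this read-out higher numbers stand for fast clearance and lower numbers for slow clearance), compound 3 (`Cc1ccc(S(=O)(=O)N(C)C(C)C)cc1C#Cc1cc(Cl)ccc1OCC(=O)O`) gives 64 mL.min-1.g-1 as the only true number in this small set. Compound 1 (`CCCS(=O)(=O)c1cccc(C#Cc2cc(Cl)ccc2OCC(=O)O)c1`) reads < 10 mL.min-1.g-1 and that is a limit of the assay. Compound 2 (`CCCS(=O)(=O)c1ccc(F)c(C#Cc2cc(Cl)ccc2OCC(=O)O)c1`) reads < 10 mL.min-1.g-1 and that too is a limit. Compound 4 (`Cc1ccc(S(=O)(=O)N(C)C)cc1C#Cc1cc(Cl)ccc1OCC(=O)O`) differs from compound 3 thus: methyl in place of isopropyl on a sulfonamide nitrogen in short, methyl in place of isopropyl on a sulfonamide nitrogen. Among the measured compounds shown here, the one measured step is a step that the two limits leave unreadable from compound 1 to compound 2 for fluoro in place of hydrogen on an aromatic carbon. That is a different change and offers no size to carry over. The estimated move is a 1.4-fold lower number from compound 3 to compound 4 (0.15 log units; within the scatter) and it is expected to stay within the usual scatter. Compound 4 is expected at 45 mL.min-1.g-1 within a range of 15 mL.min-1.g-1 to 110 mL.min-1.g-1 by this estimate.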

Compound 4, intrinsic clearance in microsomes: 22 mL.min-1.g-1
The estimate for compound 4 lay 2.0-fold (0.31 log units) above the measured number; measured number inside the range.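

In this assay, swapping isopropyl for methyl on the sulfonamide nitrogen gives a 2.9-fold lower number from compound 3 to compound 4 (0.46 log units; beyond the scatter). Among these compounds, this is the first step here with a readable size, and it shows that this one group can shift clearance beyond the scatter. The earlier pair could not show this, as compounds 1 and 2 both rest on a limit rather than a number: the limit of < 10 mL.min-1.g-1 in this assay, at which 2 of the 4 values shown sit.

From the compounds shown here alone, whether ethyl or cyclopropyl on this nitrogen would give a number between or beyond these two stays open. Also open, going by these compounds, is which difference separates compound 4 from compounds 1 and 2, which differ from it in more than one place.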